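The source may hold more compounds than are shown below. What is called first, only, known or untested is meant among the compounds shown, and "the series" means these compounds.

In an assay on cells for displacement of a labelled ligand from adenosine receptor A3 (Homo sapiens), read by scintillation counting and radioligand binding, with a stated time of 180 min, tested at 10 uM (on this read-out higher numbers stand for more inhibition at the one concentration tested (going by the name of the read-out) and lower numbers for less inhibition), three compounds of one series have been measured. Compound 2 `Clc1ccc(Cl)c(-c2nc(N3CCCCC3)c3nc[nH]c3n2)c1` gives > 80% in this assay, a limit of the assay rather than a number. Compound 3 `Clc1cccc(-c2nc(N3CCCCC3)c3nc[nH]c3n2)c1` likewise gives > 80% in this assay, again a limit. Compound 1 `Cn1cnc2c(N3CCCCC3)nc(-c3cc(Cl)ccc3Cl)nc21` gives 5.4% in this assay. The change methyl in place of hydrogen on an aromatic nitrogen therefore produces a number at least 74.6 percentage points lower from compound 2 to compound 1 (beyond the scatter). The two cores differ by hydrogen in place of chloro on an aromatic carbon, and this gives a step that the two limits leave unreadable from compound 2 to compound 3, since both values sit at the limit of > 80% in this assay, at which 2 of the 3 values shown sit.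

Compound 4 `Cn1cnc2c(N3CCCCC3)nc(-c3cccc(Cl)c3)nc21` is not yet measured in this assay. Among the compounds with values here, it differs from compound 3 by methyl in place of hydrogen on an aromatic nitrogen, the same change as the one from compound 2 to compound 1, at the same place in the shared core. Within the data shown here, on the strength of the earlier step, compound 4 is expected to show a number at least 70 percentage points lower from compound 3 to compound 4 (beyond the scatter), a drop of the same kind as the one from compound 2 to compound 1, which rests on compound 3 sitting at the limit > 80%. Compound 4 is thus estimated at 10% in this assay, with a likely range from 0% to 35%.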

Compound 4, a percentage reported as inhibition, at one concentration (the size of the read-out at that concentration, not a potency): 6.1%
Beside the measured number, compound 4's estimate is 3.9 percentage points above it, and the stated range covers the measured number.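

In this assay, methyl in place of hydrogen on an aromatic nitrogen has a large effect on the second core as well, giving a number at least 73.9 percentage points lower from compound 3 to compound 4 (beyond the scatter). Set beside the earlier step, the two read: the same change on two cores in this assay, a number at least 74.6 percentage points lower (beyond the scatter) from compound 2 to compound 1 and a number at least 73.9 percentage points lower (beyond the scatter) from compound 3 to compound 4; the limit leaves it open whether they differ This shows a large drop on both cores but not its true size on either, as the starting values of compound 2 and compound 3 are both limits of the assay, and with the methyl in place, hydrogen in place of chloro on an aromatic carbon gives a number 0.7 percentage points higher from compound 1 to compound 4 (within the scatter), whereas the corresponding step without the methyl cannot be read.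

The compounds shown leave open whether an ethyl group or a longer chain on that nitrogen would give a drop like that seen with methyl. They also leave open whether the drop would recur with a fluoro or methoxy group on the aromatic ring in place of chloro.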